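The compounds below may be only part of what the source reports. "The series", "measured", "known", "first", "only" and "open" are said of these compounds alone.

Compound 1 `OC[C@H]1O[C@@H](n2cnc3c(NCc4ccccc4)nccc32)C[C@@H]1O` gives 15% in a functional assay (Homo sapiens) for inhibition of Nucleic Acid, tested at 100 uM (a lower number here means less inhibition, a higher number more inhibition at the concentration tested (going by the name of the read-out)), the lowest of the two numbers in hand; compound 2 `C[C@H]1OC(n2cnc3c(N)nccc32)[C@H](O)[C@@H]1O` gives 18% in this assay, a value within the scatter of compound 1. For the measured compounds named here, no step between measured compounds with a single change is available, so nothing itself sets the size of the next move. Compound 3 `OC[C@H]1O[C@@H](n2cnc3cnccc32)C[C@@H]1O` differs from compound 1 by hydrogen in place of benzylamino on an aromatic carbon. Going by the values given here, with no comparable step measured, the expected step of a number 1 percentage points lower from compound 1 to compound 3 (within the scatter) is small and not beyond the scatter. Compound 3 is estimated at 14% in this assay, between 0% and 30%.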

Compound 3, a percentage reported as inhibition, at one concentration (the size of the read-out at that concentration, not a potency): 6%
Compound 3: middle estimate off by 8 percentage points, on the high side; the measured number falls inside the stated range.
By their numbers in this assay, from the lowest: compounds 3, 1 and 2 (each within the scatter of the next, the first and the last beyond it).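

In this assay, hydrogen in place of benzylamino on an aromatic carbon, next to the ring nitrogen, gives a number 9 percentage points lower from compound 1 to compound 3 (within the scatter). This first single-place step in the series shows that the whole benzylamino group can leave this position without a change beyond the scatter. No measurement available here explains the size of this step.

On these data alone, whether a methoxy group or a longer chain such as phenethylamino at this carbon would move the number beyond the scatter remains open. Changes elsewhere on the shared core also remain open.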